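Ethynyl to bromo on the triazole of compound 2

The source may report more compounds than this note shows. Statements on the series, on what has been measured and on what is new or still open speak of the compounds shown alone.

Measured compounds:
Compound 1 `O=Cc1cn(C[C@H]2CN(c3ccc(C4=CCS(=O)(=O)CC4)c(F)c3)C(=O)O2)nn1`: 3200 nM
Compound 2 `C#Cc1cn(C[C@H]2CN(c3ccc(C4=CCS(=O)(=O)CC4)c(F)c3)C(=O)O2)nn1`: > 200000 nM

Compound 1, with the structure `O=Cc1cn(C[C@H]2CN(c3ccc(C4=CCS(=O)(=O)CC4)c(F)c3)C(=O)O2)nn1`, gives 3200 nM in an assay for binding affinity to Amine oxidase [flavin-containing] A (Homo sapiens); a lower number here means a stronger inhibitor, a higher number a weaker inhibitor. Compound 2, with the structure `C#Cc1cn(C[C@H]2CN(c3ccc(C4=CCS(=O)(=O)CC4)c(F)c3)C(=O)O2)nn1`, reaches in this assay only the limit > 200000 nM, which is a limit of the assay and not a number (the limit of > 200000 nM in this assay, at which 1 of the 2 values shown sits). Going by the values given here, the one measured step, an at least 62-fold higher number from compound 1 to compound 2 (1.79 log units; beyond the scatter), replaced formyl by ethynyl and was large. Compound 3, `O=C1O[C@@H](Cn2cc(Br)nn2)CN1c1ccc(C2=CCS(=O)(=O)CC2)c(F)c1`, differs from compound 2 by bromo in place of ethynyl on an aromatic carbon. Among the compounds with values here, no measured step covers bromo, so no direction beyond the scatter can be predicted, and compound 3 is expected to stay weak, near 100000 nM within 10000 nM to 300000 nM, a step of an at least 2.0-fold lower number from compound 2 to compound 3 (0.30 log units; that floor lies within the scatter) that is estimated only roughly.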

Compound 3, inhibition constant: 16000 nM
For compound 3 the middle estimate is 6.3-fold (0.80 log units) above the measured one; the range from low to high includes it.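

Replacing ethynyl with bromo on this aromatic carbon of the triazole recovers measurable binding in this assay, with an at least 12-fold lower number from compound 2 to compound 3 (1.09 log units; beyond the scatter). Bromo still falls short of formyl, with a 5.0-fold higher number from compound 1 to compound 3 (0.70 log units; beyond the scatter), so these three groups at this position give clearly different results. Compound 2 stands at a limit of the assay and not at a number, so its step to bromo has only a lower bound: the limit of > 200000 nM in this assay, at which 1 of the 3 values shown sits.

From the compounds shown here alone, whether an amine, a carboxylic acid or a longer chain here would match or pass formyl remains open. Three groups are too few to show a rule for this position.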